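One Flipped Stereocentre, Same Atoms, Growth Inhibition Unknown

The source may hold more compounds than are shown below. What is called first, only, known or untested is meant among the compounds shown, and "the series" means these compounds.

Compound 1 `Cc1cn([C@H]2C[C@H](CC3=CC(=O)C(=O)C=C3)[C@@H](CO[Si](C)(C)C(C)(C)C)O2)c(=O)[nH]c1=O` has no result reported
Compound 2 `COc1ccc(C2([C@H]3C[C@H](n4cc(C)c(=O)[nH]c4=O)O[C@@H]3CO[Si](C)(C)C(C)(C)C)SCCCS2)cc1OC` gives 3800 nM

In a functional assay on DMS-273 cells (Homo sapiens) for inhibition, read by sulforhodamine B assay, with a stated time of 48 h (a lower number here means a stronger inhibitor of growth, a higher number a weaker inhibitor of growth), compound 2 gives 3800 nM as the only number shown, so it cannot yet be ranked against anything. Compound 3 `COc1ccc(C2([C@H]3C[C@@H](n4cc(C)c(=O)[nH]c4=O)O[C@@H]3CO[Si](C)(C)C(C)(C)C)SCCCS2)cc1OC` awaits measurement, and the change from compound 2 is this: the two compounds have the same atoms and bonds and differ only in configuration as drawn: 1 of 3 stereo elements differ; a stereocentre at a saturated ring carbon is drawn R in compound 2 and S in compound 3 and nothing else. For the measured compounds named here, no measured pair shows what such a change does here, so the expected size rests only on compound 2 at 3800 nM and remains uncertain. The expected move is a 1.2-fold higher number from compound 2 to compound 3 (0.07 log units; within the scatter) and is estimated to stay within the usual scatter, with no clear direction. Compound 3 is expected at 4500 nM (range 1500 nM to 13000 nM).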

Compound 3, concentration for 50% growth inhibition: 4570 nM
Beside the measured number, compound 3's estimate is 1.0-fold (0.01 log units) below it; the range from low to high includes it.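

In this assay, redrawing the stereocentre at the saturated ring carbon from R to S gives a 1.2-fold higher number from compound 2 to compound 3 (0.08 log units; within the scatter). A single number could not show this, but the pair now does: at this position, and with this core, the change in configuration leaves growth inhibition within the usual scatter. The comparison is a clean one, as only one thing varies: the fact that compounds 2 and 3 differ only in the configuration as drawn

Going by these compounds, whether configuration at this carbon stays as unimportant with other groups on the core remains open. An amine or a carboxylic acid attached there might give a different answer.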